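The source may hold more compounds than are shown below. What is called first, only, known or untested is meant among the compounds shown, and "the series" means these compounds.

Notes on the series. The shared core is that of compound 1 `O=C(NC1CCN(Cc2cccc(Br)c2)CC1)c1cccc2ccccc12`, and the three measured compounds vary only in the group on a saturated chain carbon bound to an amine nitrogen in a ring. In an assay on isolated protein for displacement of a labelled ligand from D(4) dopamine receptor (Homo sapiens) (on this read-out higher numbers stand for weaker inhibition and lower numbers for stronger inhibition), compound 1 gives 66 nM. Compound 2 `O=C(NC1CCN(Cc2ccc(Br)cc2)CC1)c1cccc2ccccc12` gives 44 nM in this assay, and compound 3 `O=C(NC1CCN(Cc2cccc(C(F)(F)F)c2)CC1)c1cccc2ccccc12` gives 119 nM in this assay. Compound 3 is separated from compound 2 by a 2.7-fold higher number from compound 2 to compound 3 (0.43 log units; beyond the scatter), whereas its separation from compound 1, a 1.8-fold higher number from compound 1 to compound 3 (0.26 log units; within the scatter), is within the scatter, as is a 1.5-fold lower number from compound 1 to compound 2 (0.18 log units; within the scatter).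

Compound 4 `O=C(NC1CCN(Cc2ccc(C(F)(F)F)cc2)CC1)c1cccc2ccccc12` differs from compound 3 by 4-(trifluoromethyl)phenyl in place of 3-(trifluoromethyl)phenyl on a saturated chain carbon bound to an amine nitrogen in a ring. Going by the values given here, the only measured step of the same kind is the move from the 3-bromophenyl to the 4-bromophenyl analogue, a 1.5-fold lower number from compound 1 to compound 2 (0.18 log units; within the scatter), which did not leave the scatter. With that single precedent, no step beyond the scatter is expected in this assay from compound 3 to compound 4, with at most a slightly lower number. Compound 4 is therefore estimated at 85 nM in this assay, within a range of 40 nM to 180 nM. The step this estimate implies is expected to be a 1.4-fold lower number from compound 3 to compound 4 (0.15 log units; within the scatter).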

Compound 4, inhibition constant: 96 nM
Compound 4: the middle estimate sits 1.1-fold (0.05 log units) below what was measured; the range from low to high includes it.
By their numbers in this assay, from the lowest: compounds 2, 1, 4 and 3 (each within the scatter of the next, the first and the last beyond it).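

In this assay the change from 3-(trifluoromethyl)phenyl to 4-(trifluoromethyl)phenyl gives a 1.2-fold lower number from compound 3 to compound 4 (0.09 log units; within the scatter) and so stays as small as the matching bromo step, which means that neither pair separates the two named phenyl groups at this position. The change from the 3-bromophenyl of compound 1 gives a 1.5-fold higher number from compound 1 to compound 4 (0.16 log units; within the scatter) while the change from the 4-bromophenyl of compound 2 gives a 2.2-fold higher number from compound 2 to compound 4 (0.34 log units; beyond the scatter) and leaves the scatter, so compound 2 now stands apart from both trifluoromethyl compounds but not from compound 1. Trifluoromethyl in place of bromo on an aromatic carbon can now be read twice, and the two readings agree in size: the same change on two cores in this assay, a 1.8-fold higher number (0.26 log units; within the scatter) from compound 1 to compound 3 and a 2.2-fold higher number (0.34 log units; beyond the scatter) from compound 2 to compound 4, 1.2-fold (0.08 log units) apart, within the scatter of two such steps.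

With only bromo and trifluoromethyl on the phenyl ring, the series cannot yet say how far this flat response extends, and a chloro, methoxy or nitrile group at the same places would test it. On these data alone, whether the small gap between compound 2 and compound 1 holds up on repetition also stays open, as does the effect of a longer chain in place of the single saturated carbon bound to the ring nitrogen.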